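Working notes: from compound 2 to compound 4

The source may report more compounds than this note shows. Statements on the series, on what has been measured and on what is new or still open speak of the compounds shown alone.

compound 1 `CCOc1ccc(/C=N/NC(=O)COc2cccc3ccccc23)cc1O` gives 6.23 ug/mL
compound 2 `O=C(COc1cccc2ccccc12)N/N=C/c1cccc(O)c1` gives 32.6 ug/mL
compound 3 `O=C(COc1cccc2ccccc12)N/N=C/c1cccc([N+](=O)[O-])c1` gives 12.1 ug/mL

In an ADME assay on MT4 cells (Homo sapiens) for cytotoxicity, read by MTT assay, with a stated time of 4 days (on this read-out higher numbers stand for lower toxicity in this test and lower numbers for higher toxicity in this test), compound 2 holds the highest of the three numbers with 32.6 ug/mL and stands beyond the scatter from both of the others. The next compound to be measured is compound 4 `CSc1ccc(/C=N/NC(=O)COc2cccc3ccccc23)cc1` and its difference from compound 2 is 4-(methylsulfanyl)phenyl in place of 3-hydroxyphenyl on a carbon with a double bond to nitrogen with the rest of the structure shared.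

Going by the values given here, two measured steps bear on this change, and both are modest. One is a 2.7-fold lower number from compound 2 to compound 3 (0.43 log units; beyond the scatter) where nitro takes the place of hydroxy. The other is a 5.2-fold higher number from compound 1 to compound 2 (0.72 log units; beyond the scatter) where hydrogen takes the place of ethoxy. In both pairs compound 2 has the higher number, and neither pair goes against that reading, though it rests on these two steps alone. Among the compounds with values here, no measured compound carries methylsulfanyl, so the size of the step remains uncertain and the range must stay wide.

A modest drop is therefore expected, and the estimated step is a 2.2-fold lower number from compound 2 to compound 4 (0.34 log units; beyond the scatter) in this assay on this basis. For compound 4 the estimate is 15 ug/mL with an expected range from 5 ug/mL to 40 ug/mL for now.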

Compound 4, half-maximal cytotoxic concentration: 68.3 ug/mL
Compound 4: middle estimate off by 4.6-fold (0.66 log units), on the low side; the measured number lies above the stated range.
By their numbers in this assay, from the lowest: compounds 1 and 3 (each within the scatter of the next); then compound 2; then compound 4.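

In this assay, the group on the carbon with a double bond to nitrogen can change from 3-hydroxyphenyl to 4-(methylsulfanyl)phenyl, dropping the hydrogen-bond donor, with a rise rather than a fall in the number, a 2.1-fold higher number from compound 2 to compound 4 (0.32 log units; beyond the scatter), so the hydroxy of compound 2 is not needed for a high number here. Loss of that hydroxy therefore does not set the direction on its own, since nitro in its place gave a step the other way, a 2.7-fold lower number from compound 2 to compound 3 (0.43 log units; beyond the scatter), and the outcome depends on what enters. No measurement available on these compounds accounts for the rise, so its cause stays unassigned.

The swap from 3-hydroxyphenyl to 4-(methylsulfanyl)phenyl changes both the substituent and its placing on the ring, and the compounds shown do not separate these two contributions, so 3-(methylsulfanyl)phenyl and 4-hydroxyphenyl would be the direct tests. Going by these compounds, it also remains open whether the higher number is particular to methylsulfanyl or extends to other groups on this phenyl ring, such as an amine, a carboxylic acid or a longer alkylsulfanyl chain.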